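Working notes: hydroxy in place of pentyl, one assay

The source may hold more compounds than are shown below. What is called first, only, known or untested is meant among the compounds shown, and "the series" means these compounds.

Measured so far:
compound 1 `CCCCCc1ccc(Nc2ccc3c(c2)C(=O)N(C2CCC(=O)NC2=O)C3=O)cc1`: 12%
compound 2 `COc1ccc(Nc2cccc3c2C(=O)N(C2CCC(=O)NC2=O)C3=O)cc1`: 13%

In an assay on FRT-Jurkat cells for inhibition of nuclear factor NF-kappa-B complex (Homo sapiens), read by flow cytometry, with a stated time of 24 h, tested at 10 uM (on this read-out higher numbers stand for more inhibition at the one concentration tested (going by the name of the read-out) and lower numbers for less inhibition), compound 1 gives 12%. Compound 2 gives 13%, and the two numbers lie within the scatter of each other, so neither stands apart.

Compound 3 `O=C1CCC(N2C(=O)c3ccc(Nc4ccc(O)cc4)cc3C2=O)C(=O)N1` is not yet measured. It differs from compound 1 by hydroxy in place of pentyl on an aromatic carbon. Within the data shown here, no step between measured compounds covers this change, and the two values to hand give no direction; a step no larger than the scatter is expected, either way.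

For compound 3 a value of 12% is expected, in the range 0% to 30%. The expected step is no change at the digits printed from compound 1 to compound 3 (within the scatter).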

Compound 3, a percentage reported as inhibition, at one concentration (the size of the read-out at that concentration, not a potency): 4%
Compound 3: the middle estimate sits 8 percentage points above what was measured, and the stated range covers the measured number.
By their numbers in this assay, from the lowest: compounds 3, 1 and 2 (each within the scatter of the next).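

In this assay, hydroxy in place of pentyl on an aromatic carbon, para to a large group, gives a number 8 percentage points lower from compound 1 to compound 3 (within the scatter). At this position, the read-out therefore does not separate these two groups, despite the difference in size and in hydrogen-bond donors and acceptors counted between them. No supporting measurement bears on this result.

Still open, from the compounds shown here alone, is whether an amine, a carboxylic acid or a chain longer than pentyl at this position would give a number beyond the scatter of compound 1. Also open, going by these compounds, is whether any such group would do so on the core of compound 2.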